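The source may hold more compounds than are shown below. What is called first, only, known or untested is meant among the compounds shown, and "the series" means these compounds.

Among the compounds with values here, compound 2 `FC(F)(F)c1ccc(Nc2ccc(N3CC4CC(C3)N4)cn2)cc1` is one of three compounds measured in an assay on HEK293 cells for displacement of a labelled ligand from Neuronal acetylcholine receptor; alpha3/beta4 (Homo sapiens) (a lower number here means a stronger inhibitor, a higher number a weaker inhibitor), where compound 2 gives 0.818 nM. Its number is the lowest of the three, yet neither of the others is separated from it by more than the usual scatter: compound 3 `FC(F)(F)c1ccc(Nc2cncc(N3CC4CC(C3)N4)c2)cc1` gives 1.02 nM in this assay, and compound 1 `Clc1ccc(Nc2cncc(N3CC4CC(C3)N4)c2)cc1` gives 1.2 nM. The three compounds thus sit together, and no ranking among them can be read from these numbers. Within the data shown here, the only measured step between compounds that differ in a single place is a 1.2-fold lower number from compound 1 to compound 3 (0.07 log units; within the scatter), which swaps one group on an aromatic carbon and leaves the number essentially where it was.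

Compound 4 `Fc1ccc(Nc2ccc(N3CC4CC(C3)N4)cn2)cc1` has not yet been measured. It differs from compound 2 in one place: fluoro in place of trifluoromethyl on an aromatic carbon. Among the measured compounds shown here, this change also concerns a single group on an aromatic carbon, and the one measured step of that kind showed no movement beyond the scatter. For the measured compounds named here, no measured pair compares a fluoro directly with a trifluoromethyl, so the expectation rests only on the stillness of the numbers across the three compounds. The step of a 1.6-fold higher number from compound 2 to compound 4 (0.20 log units; within the scatter) is therefore expected to stay within the scatter. The estimate for compound 4 in this assay is 1.3 nM, with a range from 0.5 nM to 3.5 nM.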

Compound 4, inhibition constant: 13 nM
Compound 4: the middle estimate sits 10-fold (1.00 log units) below what was measured, outside the stated range (above it).
By their numbers in this assay, from the lowest: compounds 2, 3 and 1 (each within the scatter of the next); then compound 4.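

In this assay, within the data shown here, the change to fluoro gives a 16-fold higher number from compound 2 to compound 4 (1.20 log units; beyond the scatter) and shows that the group on this aromatic carbon, para to a large group, is not freely exchangeable, as the earlier compounds alone had left it looking. The earlier 1.2-fold lower number from compound 1 to compound 3 (0.07 log units; within the scatter) came with trifluoromethyl in place of chloro on a different core and stayed within the scatter, so the stillness seen there covers those two groups and does not carry over to the replacement of trifluoromethyl, with its four heavy atoms, by fluoro, with its one. Nothing available accounts for the size of this step.

The compounds shown leave open whether fluoro stands alone in this or whether other groups at this position, such as methyl, methoxy or nitrile, would stay close to trifluoromethyl or fall away with fluoro. Also open, as far as these compounds go, is whether fluoro on the core of compound 1 would bring a step of similar size, or whether the step belongs to the core of compound 2 only.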